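Cyclopropyl in Place of Methyl: Expected Stability

A few compounds are considered here, and "the series" means these few. Any claim that something is new, unique, unknown or untested is made for them only; others in the source may bear on it.

Compound 1 `C[C@H](Nc1nc(N)ncc1C#N)c1cc2ccc(F)cn2c(=O)c1-c1ccccc1`: 90%
Compound 2 `Cc1c([C@H](C)Nc2ncnc(N)c2C#N)c(-c2ccc(F)cc2)c2ccc(F)cn2c1=O`: "not determined" (no result reported)

Two compounds were examined in an ADME assay on microsomes from liver (Homo sapiens), read by LC-MS, using NADPH, with a stated time of 30 min, tested at 1 uM; on this read-out lower numbers stand for a less stable compound and higher numbers for a more stable compound. Compound 1 gives 90% there, a high value. Compound 2 gives "not determined" (no result reported) in this assay, so it stands nowhere on the scale and offers no anchor of its own.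

Compound 3 `C[C@H](Nc1ncnc(N)c1C#N)c1c(C2CC2)c(=O)n2cc(F)ccc2c1-c1ccc(F)cc1` differs from compound 2 in one place: cyclopropyl in place of methyl on an aromatic carbon. Among the compounds with values here, no step between two measured compounds is available for this assay, so the size of this change cannot be read from the data. The expectation is a shift of modest size, downward if anything, or none beyond the scatter. The only measured point, compound 1, stays largely intact because of 90%. Compound 3 is therefore expected to give 70%, with a range from 35% to 95%.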

Compound 3, percent of the compound remaining: 93%
Compound 3: middle estimate off by 23 percentage points, on the low side; measured number inside the range.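

Compound 2 gives "not determined" (no result reported) in this assay and compound 3 gives 93% so no step can be read between them. On these data alone, how far cyclopropyl in place of methyl moves stability therefore stays open. No supporting data bear on this result.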